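Ester in Place of the Aminopropyl Amide

A few compounds are considered here, and "the series" means these few. Any claim that something is new, unique, unknown or untested is made for them only; others in the source may bear on it.

Among the compounds with values here, compound 2 `CC(C)(C)c1ccc(C(=O)N2CCC3(CC2)C(=O)N(CC(=O)NCCCN)CN3c2ccccc2)cc1` gives the highest of the two numbers so far in an assay on HEK293 cells for displacement of a labelled ligand from NPC1-like intracellular cholesterol transporter 1 (Homo sapiens) (on this read-out lower numbers stand for stronger inhibition and higher numbers for weaker inhibition), namely 4200 nM. Compound 1 `CC1(C)CC(OC(=O)CN2CN(c3ccccc3)C3(CCN(C(=O)c4ccc(C5CCCCC5)cc4)CC3)C2=O)CC(C)(C)N1` gives 600 nM in this assay. Compound 3 `CC1(C)CC(OC(=O)CN2CN(c3ccccc3)C3(CCN(C(=O)c4ccc(C(C)(C)C)cc4)CC3)C2=O)CC(C)(C)N1` carries (2,2,6,6-tetramethylpiperidin-4-yl)oxy in place of (3-aminopropyl)amino on a carbonyl carbon. Within the data shown here, no single-change step between measured compounds is known, so the size of this change remains open. The estimated step of a 4.2-fold lower number from compound 2 to compound 3 (0.62 log units; beyond the scatter) points toward a lower number, beyond the scatter. Compound 3 is therefore expected to reach about 1000 nM in this assay, within a range from 300 nM to 3500 nM.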

Compound 3, half-maximal inhibitory concentration: 1300 nM
For compound 3 the middle estimate is 1.3-fold (0.11 log units) below the measured one; low and high end bracket the measured number.
By their numbers in this assay, from the lowest: compound 1; then compound 3; then compound 2.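

In this assay, (2,2,6,6-tetramethylpiperidin-4-yl)oxy in place of (3-aminopropyl)amino on a carbonyl carbon gives a 3.2-fold lower number from compound 2 to compound 3 (0.51 log units; beyond the scatter), so this position accepts the larger ring-bearing group with a modest gain. The group on the aromatic carbon counts as well: tert-butyl in place of cyclohexyl gives a 2.2-fold higher number from compound 1 to compound 3 (0.34 log units; beyond the scatter). Nothing available explains either step.

As far as these compounds go, the ester oxygen and the piperidine ring enter together, so their shares in the step stay open. A (2,2,6,6-tetramethylpiperidin-4-yl)amino group or a simple ethoxy group at this carbonyl carbon would separate them.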